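Methoxy for hydrogen on an anilinoenone scaffold

The source may hold more compounds than are shown below. What is called first, only, known or untested is meant among the compounds shown, and "the series" means these compounds.

Measured compounds:
Compound 1, `COc1cc(OC)c2sc(-c3ccc(N/C=C\C(=O)c4cc(OC)c(OC)c(OC)c4Br)c(C)c3)nc2c1`, 16000 nM
Compound 2, `COc1ccc(C(=O)/C=C\Nc2ccc(-c3nc4cc(OC)c(OC)c(OC)c4s3)cc2)cc1[N+](=O)[O-]`, 15900 nM
Compound 3, `COc1cc(C(=O)/C=C\Nc2ccc(-c3nc4cc(OC)c(OC)c(OC)c4s3)cc2)cc([N+](=O)[O-])c1OC`, 15800 nM

In a functional assay on MIA PaCa-2 cells (Homo sapiens) for antiproliferative activity, read by sulforhodamine B assay, with a stated time of 48 h (on this read-out higher numbers stand for weaker inhibition and lower numbers for stronger inhibition), the three measured compounds give numbers that lie within the scatter of one another, so no order can be read among them. Compound 2 and compound 3 differ by one change, (methoxy in place of hydrogen on an aromatic carbon), and the step of a 1.0-fold lower number from compound 2 to compound 3 (0.00 log units; within the scatter) is within the scatter. The difference between the cores of compound 1 and compound 2 is not broken down here. Compound 4, `COc1cc(C(=O)/C=C\Nc2ccc(-c3nc4cc(OC)c(OC)c(OC)c4s3)cc2C)c(Br)c(OC)c1OC`, is not yet measured; it differs from compound 1 by methoxy in place of hydrogen on an aromatic carbon. This is the same kind of change as that from compound 2 to compound 3, not the same: in compound 4 the carbon is ortho to two methoxy groups, meta to a fused ring and para to a fused ring, whereas in compound 3 it is ortho to a methoxy group, meta to a large group and meta to a nitro group. Because a 1.0-fold lower number from compound 2 to compound 3 (0.00 log units; within the scatter) was within the scatter, the step of no change at the digits printed from compound 1 to compound 4 (within the scatter) is expected to be of similar size. For compound 4 the estimate in this assay is 16000 nM, expected to fall between 6000 nM and 40000 nM.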

Compound 4, half-maximal inhibitory concentration: 24300 nM
For compound 4 the middle estimate is 1.5-fold (0.18 log units) below the measured one; the measured number falls inside the stated range.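

In this assay, methoxy in place of hydrogen on an aromatic carbon gives a 1.5-fold higher number from compound 1 to compound 4 (0.18 log units; within the scatter), and the step agrees with the earlier one on the other core: the same change on two cores in this assay, a 1.0-fold lower number (0.00 log units; within the scatter) from compound 2 to compound 3 and a 1.5-fold higher number (0.18 log units; within the scatter) from compound 1 to compound 4, 1.5-fold (0.18 log units) apart, within the scatter of two such steps. On these two cores, then, the change leaves the number within the scatter, and the cores do not differ in how they take it. Two pairs cannot speak for the whole series, and neither step shows any effect of methoxy that could be said to carry over.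

The compounds shown leave open whether an amine or a longer alkoxy chain on that aromatic carbon would move the number beyond the scatter. They also leave open what a carboxylic acid in place of the bromine or the nitro group would do.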